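Cyclobutylamino in Place of Propylamino on a Triazolopyrimidine Series

This account rests on a few compounds, and the source may have more. Where it says the series, first, only, none or still open, it means among the compounds named here.

Measured compounds:
compound 1, `CCCCCCNc1nc(-c2ccccc2)nc2c1nnn2Cc1ccccc1`: 13200000 nM
compound 2, `OC1CCC(Nc2nc(-c3ccccc3)nc3c2nnn3Cc2ccccc2)CC1`: 2700000 nM
compound 3, `CCCNc1nc(-c2ccccc2)nc2c1nnn2Cc1ccccc1`: 37000000 nM

In an assay on isolated protein for binding affinity to adenosine receptor A1 (Bos taurus) (on this read-out higher numbers stand for weaker inhibition and lower numbers for stronger inhibition), compound 3 gives the highest of the three numbers; the nearest is compound 1 at a 2.8-fold higher number from compound 1 to compound 3 (0.45 log units; beyond the scatter), the furthest compound 2 at a 14-fold higher number from compound 2 to compound 3 (1.14 log units; beyond the scatter). Compound 4, `c1ccc(Cn2nnc3c(NC4CCC4)nc(-c4ccccc4)nc32)cc1`, differs from compound 3 by cyclobutyl in place of propyl on a nitrogen on an aromatic ring. Within the data shown here, two steps bear on this: the chain shortening from hexyl to propyl, a 2.8-fold higher number from compound 1 to compound 3 (0.45 log units; beyond the scatter), and the ring-bearing change, a 14-fold higher number from compound 2 to compound 3 (1.14 log units; beyond the scatter). Both point the same way, so compound 4 is expected to give a lower number than compound 3, by a modest step of about a 3.1-fold lower number from compound 3 to compound 4 (0.49 log units; beyond the scatter). The estimate for compound 4 in this assay is 12000000 nM, with a range from 4000000 nM to 35000000 nM.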

Compound 4, inhibition constant: 5000000 nM
The estimate for compound 4 lay 2.4-fold (0.38 log units) above the measured number; the measured number falls inside the stated range.
By their numbers in this assay, from the lowest: compounds 2 and 4 (each within the scatter of the next); then compound 1; then compound 3.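

In this assay the ring of cyclobutyl on this nitrogen gives a lower number than the open propyl chain (a 7.4-fold lower number from compound 3 to compound 4 (0.87 log units; beyond the scatter)) and also than the longer hexyl chain (a 2.6-fold lower number from compound 1 to compound 4 (0.42 log units; beyond the scatter)). Compound 4 cannot be separated from compound 2 (a 1.9-fold higher number from compound 2 to compound 4 (0.27 log units; within the scatter)), so at this position cyclobutyl, which carries no hydroxyl, reads the same as 4-hydroxycyclohexyl. No evidence here accounts for these steps.

Whether ring size matters remains open, as cyclopentyl and unsubstituted cyclohexyl do not appear among these compounds. Going by these compounds, how a hydroxyl on the cyclobutyl ring would read also remains open.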